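Bromo for fluoro: a halogen swap on compound 2

The source may report more compounds than this note shows. Statements on the series, on what has been measured and on what is new or still open speak of the compounds shown alone.

Measured compounds:
compound 1, `O=C(Nc1cc(-c2ccccc2)nn1-c1ccccc1)c1cc([N+](=O)[O-])cc([N+](=O)[O-])c1`: "not determined" (no result reported) in an assay on HEK293 cells for displacement of a labelled ligand from metabotropic glutamate receptor 5 (Rattus norvegicus); a higher number here means a weaker inhibitor, a lower number a stronger inhibitor
compound 2, `O=C(Nc1cc(-c2ccccc2)nn1-c1ccccc1F)c1ccccc1`: 2700 nM

Among the compounds with values here, compound 2 is the only compound with a number in this assay, where compound 2 gives 2700 nM. Within the data shown here, compound 1 was not measured, so compound 2 has nothing to be compared with and no step between measured compounds can be read.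

Compound 3 is `O=C(Nc1cc(-c2ccccc2)nn1-c1ccccc1Br)c1ccccc1`. It differs from compound 2 by bromo in place of fluoro on an aromatic carbon. Among the measured compounds shown here, since no measured pair shows what this kind of exchange does here, the direction has to be guessed. A change of a single heavy atom at the same place is expected to move the value only modestly, and a step of a 1.4-fold lower number from compound 2 to compound 3 (0.13 log units; within the scatter) toward the stronger side is estimated, close to the scatter. Compound 3 is therefore expected to give about 2000 nM in this assay, within a range from 600 nM to 6500 nM.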

Compound 3, inhibition constant: 2600 nM
For compound 3 the middle estimate is 1.3-fold (0.11 log units) below the measured one; measured number inside the range.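

Swapping 2-fluorophenyl for 2-bromophenyl gives the first reading of any change at this place, and it amounts to a 1.0-fold lower number from compound 2 to compound 3 (0.02 log units; within the scatter) in this assay with no difference that can be told apart from the scatter. On this aromatic carbon, ortho to a large group, fluoro and bromo therefore serve equally well in this pair, and the size of the halogen atom does not separate the two values. Nothing at hand accounts for this result.

The compounds shown leave open whether a group other than a halogen at this place, such as an amine, a methoxy group or a carboxylic acid, would give a different value. They also leave open how a nitrile or a longer chain elsewhere on the shared core would read in this assay alongside these two compounds.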